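An Endoperoxide Epimer Measured Against a Weak Parent

The source may report more compounds than this note shows. Statements on the series, on what has been measured and on what is new or still open speak of the compounds shown alone.

Compound 1 `C=C1CCC[C@@H]2[C@@H](CC[C@@]3(C)CC[C@H]([C@H](C)C(=O)O)OO3)[C@H](C)CC[C@@]12C` provides the reference point: in a functional assay on IGRO cells (Homo sapiens) for cytotoxicity, read by colony formation (a lower number here means a stronger inhibitor of growth, a higher number a weaker inhibitor of growth), compound 1 gives 100 nM. Compound 2 `C=C1CCCC(C)(C)C1(O)CC/C(C)=C/CC[C@]1(C)CC[C@H]([C@@H](C)C(=O)OC)OO1` stands elsewhere. In this assay compound 2 gives > 5000 nM, which is a limit of the assay and not a measured number. Compound 2 thus sits at the limit of > 5000 nM in this assay, at which 1 of the 2 values shown sits, so its true potency is not pinned down, only bounded. Compound 3 `C=C1CCCC(C)(C)C1(O)CC/C(C)=C/CC[C@]1(C)CC[C@@H]([C@@H](C)C(=O)OC)OO1` is the compound still to be measured. Its relation to compound 2 is the two compounds have the same atoms and bonds; at least one stereo element is drawn with a configuration in one of them and without one in the other: 1 of 5 stereo elements differ; a stereocentre at a saturated ring carbon is drawn R in compound 2 and S in compound 3. Among the measured compounds shown here, no measured pair in this set shows what such a change of configuration does, so the size and direction of the step cannot be read from the data. The step is expected to be an at least 2.0-fold lower number from compound 2 to compound 3 (0.30 log units; that floor lies within the scatter), with a real chance that the result is again only a limit. Compound 3 is expected to give about 2500 nM, within a range from 300 nM to 20000 nM.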

Compound 3, concentration for 50% growth inhibition: 2420 nM
Compound 3: middle estimate off by 1.0-fold (0.01 log units), on the high side; measured number inside the range.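

Compound 3 shows that this single stereocentre at a saturated ring carbon matters in this assay: going from R to S gives an at least 2.0-fold lower number from compound 2 to compound 3 (0.31 log units; beyond the scatter) and leaves every atom and bond unchanged. The size of that step has no upper bound yet, and compound 2 gives > 5000 nM, which is a limit and not a number: the limit of > 5000 nM in this assay, at which 1 of the 3 values shown sits. The reading of this position also carries a caution: the fact that one of compounds 2 and 3 is drawn with a defined configuration and the other without, at the place where they differ.

The compounds shown leave open whether the same change of configuration would shift growth inhibition in the same direction on the core of compound 1. They also leave open what an amide in place of the methyl ester would do with the S configuration at this carbon.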